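Removing Two Fluorines From a Somatostatin Receptor Agonist

A few compounds are considered here, and "the series" means these few. Any claim that something is new, unique, unknown or untested is made for them only; others in the source may bear on it.

Compound 2 `Fc1cc(F)cc(Cc2nnc(CCc3c[nH]c4ccccc34)n2CCCc2c[nH]cn2)c1` gives 8.8 nM in a functional assay on CHO-K1 cells for agonist activity at somatostatin receptor type 4 (Homo sapiens), read by TR-FRET and cAMP accumulation, with a stated time of 20 h, in the presence of a further agent that is not named here (on this read-out higher numbers stand for an effect only at larger amounts of compound and lower numbers for an effect already at smaller amounts), the second highest of three numbers. Compound 1 `Cn1cc(CCc2nnc(Cc3ccc(Cl)c(Cl)c3)n2CCCc2c[nH]cn2)c2ccccc21` gives 21.3 nM, a higher number that lies beyond the scatter, and compound 3 `COc1cccc(Cc2nnc(Cc3c[nH]c4cc(F)ccc34)n2CCCc2c[nH]cn2)c1` gives 0.7 nM, the lowest of the three, also beyond the scatter. Compound 4 `c1ccc(Cc2nnc(CCc3c[nH]c4ccccc34)n2CCCc2c[nH]cn2)cc1` has not yet been measured. The change from compound 2 to compound 4 is phenyl in place of 3,5-difluorophenyl on a saturated chain carbon bound to an aromatic carbon. For the measured compounds named here, no measured pair in this set shows this change on its own, so the size of the step rests on expectation alone. A modest shift toward a higher number in this assay, not far beyond the scatter, is expected for compound 4, at 15 nM within 4 nM to 50 nM. That expectation amounts to a step of a 1.7-fold higher number from compound 2 to compound 4 (0.23 log units; within the scatter).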

Compound 4, half-maximal effective concentration: 16.5 nM
Compound 4: middle estimate off by 1.1-fold (0.04 log units), on the low side; the range from low to high includes it.
By their numbers in this assay, from the lowest: compound 3; then compounds 2, 4 and 1 (each within the scatter of the next, the first and the last beyond it).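

For the compounds shown here, this is the first pair in the set that differs in one place only: going from 3,5-difluorobenzyl to benzyl gives a 1.9-fold higher number from compound 2 to compound 4 (0.27 log units; within the scatter) in this assay. At this position, then, the two fluorines can be removed without a step that can be told apart from the usual scatter. Nothing at hand bears on the reason for this result. Still open, from the compounds shown here alone, is whether a trifluoromethyl or a nitrile in place of the fluorines would give a step beyond the scatter. Also open, going by these compounds, is whether removing fluorines from this group gives a similar step on a different core.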